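The compounds below may be only part of what the source reports. "The series", "measured", "known", "first", "only" and "open" are said of these compounds alone.

Of the compounds shown here, three of one family have been tested so far. Compound 1 `COc1ccc(-c2cc(/C=C/C(=O)c3cc(OC)c(OC)c(OC)c3)[nH]n2)cc1OC` gives 200 nM in a functional assay on SR cells (Homo sapiens) for inhibition, read by sulforhodamine B assay, with a stated time of 48 h; a higher number here means a weaker inhibitor of growth, a lower number a stronger inhibitor of growth. Compound 2 `COc1ccc(C(=O)/C=C/c2cc(-c3cc(OC)c(OC)c(OC)c3)n[nH]2)cc1` gives 340 nM, and compound 3 `COc1ccc(C(=O)/C=C/c2cc(-c3cc(OC)c(OC)c(OC)c3)n[nH]2)cc1OC` gives 270 nM. All three numbers lie within the usual scatter of one another, so none stands apart. Within the data shown here, the one step measured so far, a 1.3-fold lower number from compound 2 to compound 3 (0.10 log units; within the scatter), put a methoxy in place of hydrogen on an aromatic carbon and changed nothing beyond the scatter.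

Compound 4 `COc1cc(C(=O)/C=C/c2cc(-c3cc(OC)c(OC)c(OC)c3)n[nH]2)cc(OC)c1OC` repeats that kind of change on compound 3: methoxy in place of hydrogen on an aromatic carbon. Since the earlier methoxy addition, a 1.3-fold lower number from compound 2 to compound 3 (0.10 log units; within the scatter), moved the number only within the scatter, a similarly small step is expected here, a 1.1-fold lower number from compound 3 to compound 4 (0.03 log units; within the scatter). Compound 4 is therefore estimated at 250 nM, within 120 nM to 520 nM.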

Compound 4, concentration for 50% growth inhibition: 390 nM
Compound 4: the middle estimate sits 1.6-fold (0.19 log units) below what was measured; the range from low to high includes it.
By their numbers in this assay, from the lowest: compounds 1, 3, 2 and 4 (each within the scatter of the next).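

In this assay, a further methoxy on an aromatic carbon ortho to a methoxy group and meta to a large group stays within the scatter, with a 1.4-fold higher number from compound 3 to compound 4 (0.16 log units; within the scatter) and also a 2.0-fold higher number from compound 1 to compound 4 (0.29 log units; within the scatter). This change now stays within the scatter at this third methoxy place too, so no effect of it can be read. The two cores do not separate either: the same change on two cores in this assay, a 1.3-fold lower number (0.10 log units; within the scatter) from compound 2 to compound 3 and a 2.0-fold higher number (0.29 log units; within the scatter) from compound 1 to compound 4, 2.5-fold (0.39 log units) apart, within the scatter of two such steps. Still open, going by these compounds, is whether any other group at this place, such as an amine or a carboxylic acid, would move the number beyond the scatter.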